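Lengthening a Diamine Chain on a Hydroxypyridinone Amide

This account rests on a few compounds, and the source may have more. Where it says the series, first, only, none or still open, it means among the compounds named here.

Of the compounds shown here, three have been measured in a physicochemical assay, read by spectrophotometry, with a stated time of 10 min, tested at 200 uM, in the presence of a further agent that is not named here; a lower number here means a weaker effect, a higher number a stronger effect of the compound at the concentration tested. Compound 1 `NCC(N)CC(=O)N1CCN(C(=O)CCn2cccc(O)c2=O)CC1` gives 50.3%. Compound 2 `NCC(N)CCC(=O)N1CCN(C(=O)CCn2cccc(O)c2=O)CC1` gives 53.2%. The change between these two is 2,3-diaminopropyl in place of 1,2-diaminoethyl on a saturated chain carbon bound to a carbonyl carbon, and the step it made was a number 2.9 percentage points higher from compound 1 to compound 2 (within the scatter). Compound 3 `NCC(N)CCCNC(=O)CCn1cccc(O)c1=O` gives 60%; the difference between its core and the core of compound 1 is not broken down here, and its number sits within the scatter of both compound 1 and compound 2, so no order among the three can be drawn.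

Compound 4 `NCC(N)CCCCNC(=O)CCn1cccc(O)c1=O` has not yet been measured. It differs from compound 3 by 2,3-diaminopropyl in place of 1,2-diaminoethyl on a saturated chain carbon, three bonds along the chain from an amide-type nitrogen. For the measured compounds named here, this is the same kind of change as the one between compound 1 and compound 2, but not the same: there the place was on a saturated chain carbon bound to a carbonyl carbon, here it is on a saturated chain carbon, three bonds along the chain from an amide-type nitrogen. Resting on the earlier step of a number 2.9 percentage points higher from compound 1 to compound 2 (within the scatter), the expected step is a number 2 percentage points higher from compound 3 to compound 4 (within the scatter), again within the scatter. The estimate for compound 4 is 62%, with a likely span from 52% to 72%.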

Compound 4, a percentage reported as activity, at one concentration (the size of the read-out at that concentration, not a potency): 62.8%
For compound 4 the middle estimate is 0.8 percentage points below the measured one; the measured number falls inside the stated range.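

In this assay the swap of 1,2-diaminoethyl for 2,3-diaminopropyl gives a number 2.8 percentage points higher from compound 3 to compound 4 (within the scatter) on the newer core, while the same kind of change on the core of compound 1 gave a number 2.9 percentage points higher from compound 1 to compound 2 (within the scatter) in the earlier pair. For the compounds shown here, this shows only that, in these two pairs, the change produced no step that can be told apart from the ordinary spread of repeated measurements; it does not show that lengthening the chain raises the read-out on either core, nor that any real effect carries from one core to the other. Nothing measured here bears on why the numbers fall as they do.

On these data alone, what stays open is whether a still longer diamino chain would produce a step beyond the scatter on either core. Also open, as far as these compounds go, is how the read-out would respond if a single amine or a carboxylic acid stood in place of the diamino chain.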